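Moving a chloro group around the benzoyl ring

The compounds below may be only part of what the source reports. "The series", "measured", "known", "first", "only" and "open" are said of these compounds alone.

The shared core of compound 1 `O=C(Nc1cccc(/C=C/C(=O)c2nc3ccccc3[nH]2)c1)c1ccccc1` carries a benzoyl amide on one side of the molecule. Within the data shown here, in a functional assay on HCT-116 cells (Homo sapiens) for antiproliferative activity, read by MTT assay, with a stated time of 48 h (a lower number here means a stronger inhibitor, a higher number a weaker inhibitor), compound 1 gives 2440 nM, which is the highest of the two numbers measured so far. The nearest neighbour is compound 2 `O=C(/C=C/c1cccc(NC(=O)c2ccccc2Cl)c1)c1nc2ccccc2[nH]1`, where a chloro group sits on the benzoyl ring; in this assay compound 2 gives 1280 nM. The step of a 1.9-fold lower number from compound 1 to compound 2 (0.28 log units; within the scatter) therefore stays within the ordinary spread of repeated measurements.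

Compound 3 `O=C(Nc1cccc(/C=C/C(=O)c2nc3ccccc3[nH]2)c1)c1cccc(Cl)c1` is built from compound 1 by a related change: chloro in place of hydrogen on an aromatic carbon, placed on an aromatic carbon of a six-membered aromatic ring of carbon only, meta to a large group, so that the benzoyl becomes a (3-chlorophenyl)carbonyl. Among the measured compounds shown here, the only measured step that bears on this is the one from compound 1 to compound 2, which introduced the same chloro group at a different carbon of the same ring and produced no change beyond the scatter. A similarly small step is expected here, with the number going slightly lower if anything. Compound 3 is therefore estimated at 1800 nM, within a range of 700 nM to 4500 nM, which corresponds to an expected step of a 1.4-fold lower number from compound 1 to compound 3 (0.13 log units; within the scatter).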

Compound 3, half-maximal inhibitory concentration: 1120 nM
Compound 3: middle estimate off by 1.6-fold (0.21 log units), on the high side, and the stated range covers the measured number.
By their numbers in this assay, from the lowest: compounds 3, 2 and 1 (each within the scatter of the next, the first and the last beyond it).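

In this assay, among these compounds, the chloro group on an aromatic carbon, meta to a large group, gives the first step in this short series that lies beyond the scatter (a 2.2-fold lower number from compound 1 to compound 3 (0.34 log units; beyond the scatter)). The step is modest, but it shows that adding a single chlorine atom to this benzoyl ring can shift the number by more than the usual spread of repeated measurements, something the earlier step (a 1.9-fold lower number from compound 1 to compound 2 (0.28 log units; within the scatter)) could not show. The choice between the two ring carbons tried so far cannot be resolved, as compound 2 and compound 3 differ only in where the chloro group sits and their numbers remain within the scatter of each other (a 1.1-fold lower number from compound 2 to compound 3 (0.06 log units; within the scatter)).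

Nothing available here gives a reason for any of these steps. From the compounds shown here alone, it also remains open whether the step is particular to chloro, since a fluoro, a methoxy or an amine on the same carbon could give a smaller, similar or larger change in the number.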